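Replacing the (morpholin-4-yl)carbonyl group of compound 2

The source may hold more compounds than are shown below. What is called first, only, known or untested is meant among the compounds shown, and "the series" means these compounds.

In a physicochemical assay, read by spectrophotometry (on this read-out lower numbers stand for stronger inhibition and higher numbers for weaker inhibition), compound 1 `CCN(CC)C(=O)COc1ccc(-c2cc(=O)c3c(O)c(O)c(O)cc3o2)cc1` reads 81300 nM and compound 2 `O=C(Oc1ccc(-c2cc(=O)c3c(O)c(O)c(O)cc3o2)cc1)N1CCOCC1` reads 19300 nM as the lower of the two numbers. Going by the values given here, the only measured step is modest but beyond the scatter: a 4.2-fold lower number from compound 1 to compound 2 (0.62 log units; beyond the scatter) when (morpholin-4-yl)carbonyl takes the place of (diethylcarbamoyl)methyl. Compound 3 `CN(C)C(=O)COc1ccc(-c2cc(=O)c3c(O)c(O)c(O)cc3o2)cc1` shares the core of these two but has not yet been measured. It carries the change (dimethylcarbamoyl)methyl in place of (morpholin-4-yl)carbonyl on an oxygen on an aromatic ring with (dimethylcarbamoyl)methyl in place of (morpholin-4-yl)carbonyl on an oxygen on an aromatic ring. The entering group resembles the (diethylcarbamoyl)methyl of compound 1 at 81300 nM in this series, so the change is expected to undo most of that measured step. Among the compounds with values here, no measured pair separates the dimethyl and diethyl versions, so this resemblance remains untested. A modest move to a higher number, probably beyond the scatter, is therefore expected, with a 3.1-fold higher number from compound 2 to compound 3 (0.49 log units; beyond the scatter) as the estimated step in this assay for this change. For compound 3 the estimated value is 60000 nM with an expected range from 28000 nM to 120000 nM in this assay once it is measured.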

Compound 3, half-maximal inhibitory concentration: 80700 nM
The estimate for compound 3 lay 1.3-fold (0.13 log units) below the measured number; measured number inside the range.
By their numbers in this assay, from the lowest: compound 2; then compounds 3 and 1 (each within the scatter of the next).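

In this assay, the step (a 4.2-fold higher number from compound 2 to compound 3 (0.62 log units; beyond the scatter)) shows that the lower number of compound 2 does not carry over when (dimethylcarbamoyl)methyl stands on this oxygen on an aromatic ring. The exchange of diethylamino for dimethylamino on the carbonyl carbon makes no difference that can be told from the scatter (a 1.0-fold lower number from compound 1 to compound 3 (0.00 log units; within the scatter)), so among the compounds shown, compound 2, with its (morpholin-4-yl)carbonyl group, is the only one that stands apart from the other two. Nothing measured here offers an explanation for that gap.

The change from ((morpholin-4-yl)carbonyl)oxy to (dimethylcarbamoyl)methoxy alters both the link to the oxygen and the amine part of the group, and the compounds shown do not tell which of the two goes with the step. From the compounds shown here alone, a (morpholin-4-yl)carbonylmethyl group on the same oxygen, or a dimethylcarbamoyl group joined directly to it, would separate the two, and whether a piperidine in place of the morpholine would keep the lower number also remains open.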